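The source may hold more compounds than are shown below. What is called first, only, known or untested is meant among the compounds shown, and "the series" means these compounds.

Measured in a physicochemical assay for solubility, read by LC-MS, in phosphate buffer, with a stated time of 24 h, at pH 7.4; on this read-out higher numbers stand for higher solubility and lower numbers for lower solubility:
- compound 1 `CN(C)C(=O)c1cc(-c2cnc(NCc3c(F)ccc4c3CCO4)c3cn[nH]c(=O)c23)n(C)n1`: 3000 nM
- compound 2 `CC1(C)CC(=O)N(c2cnc(NCc3c(F)ccc4c3CCO4)n3cnnc23)C1`: 57000 nM
- compound 3 `CN(C)Cc1ccc2c(c1)CN(c1cnc(NCc3c(F)ccc4c3CCO4)c3cn[nH]c(=O)c13)C2=O`: 174000 nM

Compound 1 stands lowest of the three, with compound 2 and compound 3 both higher by more than the scatter. The unmeasured compound 4 `Cc1nn(C)cc1-c1cnc(NCc2c(F)ccc3c2CCO3)c2cn[nH]c(=O)c12` carries 1,3-dimethyl-1H-pyrazol-4-yl in place of the 3-(dimethylcarbamoyl)-1-methyl-1H-pyrazol-5-yl of compound 1, on an aromatic carbon (1,3-dimethyl-1H-pyrazol-4-yl in place of 3-(dimethylcarbamoyl)-1-methyl-1H-pyrazol-5-yl on an aromatic carbon). Within the data shown here, no measured pair shows this change, so the expectation is a loose one. With compound 1 at 3000 nM, the lowest of the three, a moderate rise in this assay is expected, only a little beyond the scatter. The estimated step is a 2.7-fold higher number from compound 1 to compound 4 (0.43 log units; beyond the scatter). For compound 4 the expected value is 8000 nM, with an estimated range of 1500 nM to 40000 nM.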

Compound 4, solubility: 9000 nM
The estimate for compound 4 lay 1.1-fold (0.05 log units) below the measured number; the range from low to high includes it.
By their numbers in this assay, from the lowest: compound 1; then compound 4; then compound 2; then compound 3.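

In this assay, among these compounds, 1,3-dimethyl-1H-pyrazol-4-yl replacing 3-(dimethylcarbamoyl)-1-methyl-1H-pyrazol-5-yl on this aromatic carbon gives a 3.0-fold higher number from compound 1 to compound 4 (0.48 log units; beyond the scatter) and is the first readable step at this position. The number here therefore responds to the group on this carbon, and the higher number comes with a smaller group that has no dimethylcarbamoyl. No measurement shown accounts for the step. Going by these compounds, whether the rise follows the loss of dimethylcarbamoyl or the shift from pyrazol-5-yl to pyrazol-4-yl remains open. So does the effect of a morpholine or a carboxylic acid on the pyrazole.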